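From Bromo to Chloro: A One-Atom Exchange

The compounds below may be only part of what the source reports. "The series", "measured", "known", "first", "only" and "open" are said of these compounds alone.

In an ADME assay on HepG2 cells (Homo sapiens), read by MTT assay, with a stated time of 72 h, in the presence of a further agent that is not named here (a lower number here means a stronger inhibitor, a higher number a weaker inhibitor), compound 1 (`O=C(NCc1ccccc1)Oc1ccc(Cl)cc1C(=O)Nc1ccc(Cl)cc1`) gives 6400 nM and compound 2 (`O=C(NC1CCCCC1)Oc1ccc(Cl)cc1C(=O)Nc1ccc(Br)cc1`) gives 9400 nM as its reading. Going by the values given here, these two numbers lie within the usual scatter of each other, so compound 2 stands level with the only other measured compound. Among the compounds with values here, the two differ in more than one place, and no measured step speaks directly to the exchange that comes next.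

Compound 3 (`O=C(NC1CCCCC1)Oc1ccc(Cl)cc1C(=O)Nc1ccc(Cl)cc1`) departs from compound 2 in a single place (chloro in place of bromo on an aromatic carbon) with chloro in place of bromo on an aromatic carbon, para to a large group. Within the data shown here, the data hold no measured example of this exchange. Among the measured compounds shown here, the only guide is how close compound 1 at 6400 nM and compound 2 at 9400 nM sit in this assay as measured so far. No shift beyond the scatter is expected in either direction. The expected change is a 1.2-fold lower number from compound 2 to compound 3 (0.07 log units; within the scatter) and is estimated to stay within that scatter. Compound 3 is expected at 8000 nM with an estimated range from 4000 nM to 16000 nM in this measurement.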

Compound 3, half-maximal inhibitory concentration: 33600 nM
Estimate against measurement, compound 3: 4.2-fold (0.62 log units) below, outside the stated range (above it).
By their numbers in this assay, from the lowest: compounds 1 and 2 (each within the scatter of the next); then compound 3.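

In this assay the position para to a large group proves sensitive to the halogen it carries: chloro in place of bromo gives a 3.6-fold higher number from compound 2 to compound 3 (0.55 log units; beyond the scatter) and so moves the reading beyond the scatter, something the earlier pair, which differed in more than one place, could not show. With the 4-chlorophenyl kept, the group on the amide-type nitrogen also matters, as cyclohexyl in place of benzyl gives a 5.3-fold higher number from compound 1 to compound 3 (0.72 log units; beyond the scatter) in the same direction, so both single exchanges that lead to compound 3 raise the number. Nothing in the available data accounts for either step.

The compounds shown leave open how a fluoro or a methoxy group would read at this position, and whether the exchange of bromo for chloro would have the same size with benzyl rather than cyclohexyl on the amide-type nitrogen. They also leave open how far the reading would move with an amine or a carboxylic acid on the cyclohexyl ring, and whether the 4-chlorophenyl would keep its standing there.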